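The source may hold more compounds than are shown below. What is called first, only, known or untested is meant among the compounds shown, and "the series" means these compounds.

Measured compounds in a functional assay on cardiac atrium for antagonist activity at histamine H2 receptor (Cavia porcellus), tested at 0.3 uM; a lower number here means a less potent compound, a higher number a more potent compound, by a factor of ten per unit of this negative logarithm:
compound 1 `N#CN/C(=N\CCNc1ccc(N=[N+]=[N-])cc1[N+](=O)[O-])NCCCCOc1cccc(CN2CCCCC2)c1`, 7.47
compound 2 `N#CN/C(=N\CCNC(=O)c1ccc(N)cc1)NCCCCOc1cccc(CN2CCCCC2)c1`, 7.17

Within the data shown here, compound 2 stands within the scatter of compound 1, the only other number; the step of a number 0.30 log units lower from compound 1 to compound 2 (within the scatter) is the sole measured step, and it concerns a different change. Compound 3 `N#CN/C(=N\CCNC(=O)c1ccc(N)c(I)c1)NCCCCOc1cccc(CN2CCCCC2)c1` differs from compound 2 by iodo in place of hydrogen on an aromatic carbon. Among the measured compounds shown here, no measured step bears on an iodo-for-hydrogen exchange, so nothing supports a move beyond the scatter in this assay . Compound 3 is therefore estimated near compound 2, with a number 0.03 log units higher from compound 2 to compound 3 (within the scatter) as the expected step. The estimate for compound 3 is 7.2, with a range from 6.6 to 7.8.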

Compound 3, negative logarithm of the antagonist equilibrium constant: 7.35
Beside the measured number, compound 3's estimate is 0.15 log units below it; the measured number falls inside the stated range.
By their numbers in this assay, from the lowest: compounds 2, 3 and 1 (each within the scatter of the next).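

In this assay the iodo-for-hydrogen exchange on the 4-aminophenyl group, ortho to the amino group, gives a number 0.18 log units higher from compound 2 to compound 3 (within the scatter), so this aromatic carbon carries an iodine without a shift beyond the scatter. Set against the 4-azido-2-nitrophenyl group, the (4-amino-3-iodophenyl)carbonyl group gives a number 0.12 log units lower from compound 1 to compound 3 (within the scatter), which leaves all three compounds within the scatter of one another. Nothing measured here bears on the cause of either step.

Open, on these data alone, is whether bromo, chloro or methyl on this carbon would give a similar number. Also open, as far as these compounds go, is whether the iodo exchange would read the same with a hydroxyl in place of the amino group.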